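A few compounds are considered here, and "the series" means these few. Any claim that something is new, unique, unknown or untested is made for them only; others in the source may bear on it.

Measured in a functional assay on SK-BR-3 cells (Homo sapiens) for antiproliferative activity; on this read-out lower numbers stand for stronger inhibition and higher numbers for weaker inhibition:
- compound 1 `CC(C)=CCc1cc(C(=O)Nc2cc3ccc(OCCCN(C)C4CCCCC4)c(C)c3oc2=O)ccc1O`: 970 nM
- compound 2 `CC(C)=CCc1cc(C(=O)Nc2cc3ccc(OCCCN[C@H](C)c4ccccc4)c(C)c3oc2=O)ccc1O`: 1000 nM

Compound 2, at 1000 nM, cannot be told apart from compound 1 on these numbers, since the two values lie within the usual scatter of each other. Compound 3 `CC(C)=CCc1cc(C(=O)Nc2cc3ccc(OCCCN(C)Cc4ccccc4)c(C)c3oc2=O)ccc1O` has not yet been measured. It has the same atoms as compound 2, joined differently, with benzyl(methyl)amino in place of (1-phenylethyl)amino on a saturated chain carbon, three bonds along the chain from an oxygen on an aromatic ring.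

Among the measured compounds shown here, only one measured step bears on this change. At the same place on the chain, a 1.0-fold higher number from compound 1 to compound 2 (0.01 log units; within the scatter), a swap of cyclohexyl(methyl)amino for (1-phenylethyl)amino that stayed within the scatter. The entering group keeps the six-membered aromatic ring found in compound 2 and the methyl on the amine found in compound 1. A single step is thin evidence, so the range is kept wide. The expected step, a 1.1-fold lower number from compound 2 to compound 3 (0.05 log units; within the scatter), is none beyond the scatter. Compound 3 is estimated at 900 nM, with an expected range from 400 nM to 2000 nM.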

Compound 3, half-maximal inhibitory concentration: 10700 nM
Estimate against measurement, compound 3: 12-fold (1.08 log units) below, and the stated range ends below it.
By their numbers in this assay, from the lowest: compounds 1 and 2 (each within the scatter of the next); then compound 3.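

In this assay, the end of this chain proves far less forgiving than compounds 1 and 2 suggested: benzyl(methyl)amino in place of (1-phenylethyl)amino gives an 11-fold higher number from compound 2 to compound 3 (1.03 log units; beyond the scatter), even though the two groups have the same atoms and each carries one six-membered aromatic ring, so how those atoms are joined matters a great deal here. Benzyl in place of cyclohexyl on the amine nitrogen gives an 11-fold higher number from compound 1 to compound 3 (1.04 log units; beyond the scatter), so among these three compounds neither the methyl on the nitrogen, present in compound 1, nor the aromatic ring, present in compound 2, goes with the weak result alone; only compound 3 has both on a benzyl(methyl)amino group. Nothing available here explains why this rearrangement matters so much.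

The step from compound 2 to compound 3 changes several things at once: it removes the hydrogen on the amine and the defined stereocentre, and it moves a methyl from the chain carbon to the nitrogen. Simple benzylamino and methyl(1-phenylethyl)amino groups would help separate these changes, while the mirror-image form of the (1-phenylethyl)amino group would test the stereocentre alone.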